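Swapping the benzyl arm of a weak sulfonamide for a basic chain

The source may report more compounds than this note shows. Statements on the series, on what has been measured and on what is new or still open speak of the compounds shown alone.

Compound 1: `Cc1ccc([N+](=O)[O-])cc1C(=O)N(C)/N=C/c1cnn2ccc(C#N)cc12`, 68 nM
Compound 2: `Cc1ccc([N+](=O)[O-])cc1S(=O)(=O)N(Cc1ccccc1)/N=C/c1cnn2ccc(C#N)cc12`, > 1000 nM

In an assay on isolated protein for inhibition of phosphatidylinositol 4,5-bisphosphate 3-kinase catalytic subunit beta isoform (Homo sapiens), read by 33P incorporation, with a stated time of 60 min (on this read-out lower numbers stand for stronger inhibition and higher numbers for weaker inhibition), compound 1 gives 68 nM. Compound 2 has only a limit here: > 1000 nM, which means compound 2 sits at the limit of > 1000 nM in this assay, at which 1 of the 2 values shown sits, and no exact number is known for it. Compound 3, `CCN(CC)CCN(/N=C/c1cnn2ccc(C#N)cc12)S(=O)(=O)c1cc([N+](=O)[O-])ccc1C`, differs from compound 2 by (diethylamino)methyl in place of phenyl on a saturated chain carbon bound to a sulfonamide nitrogen. Among the compounds with values here, since compound 2 gives only a limit, no measured step is available to guide the expectation, and the change may leave compound 3 weak or bring it into the measurable range. Compound 3 is therefore estimated at 1500 nM, within 300 nM to 6000 nM, which would mean an expected step that the limit leaves unreadable from compound 2 to compound 3.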

Compound 3, half-maximal inhibitory concentration: > 1000 nM
Compound 3: no number, only a limit (the forecaster's own chance of this, stated with the estimate: 55%); the middle value does not contradict the limit.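

Compound 2 and compound 3 both end in a limit, so no step can be read between them, because neither has an exact number: the limit of > 1000 nM in this assay, at which 2 of the 3 values shown sit.

The compounds shown leave open whether benzyl or 2-(diethylamino)ethyl gives the stronger inhibition.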